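Trimming the Aryl Group on a Sulfonamide Nitrogen

The compounds below may be only part of what the source reports. "The series", "measured", "known", "first", "only" and "open" are said of these compounds alone.

Compound 3 `Cc1ccc(NS(=O)(=O)c2ccc(N3CCNC3=O)cc2)c(C)c1` has the lowest number of the three measured compounds in a functional assay on M21 cells (Homo sapiens) for antiproliferative activity, read by sulforhodamine B assay, with a stated time of 48 h; a higher number here means a weaker inhibitor, a lower number a stronger inhibitor; in this assay compound 3 gives 150 nM. Compound 2 `COc1ccccc1NS(=O)(=O)c1ccc(N2CCNC2=O)cc1` gives 300 nM, which is a 2.0-fold lower number from compound 2 to compound 3 (0.30 log units; within the scatter). Compound 1 `CCc1ccc(NS(=O)(=O)c2ccc(N3CCNC3=O)cc2)cc1` gives 480 nM, which is a 3.2-fold lower number from compound 1 to compound 3 (0.51 log units; beyond the scatter). Compound 4 `Cc1cccc(NS(=O)(=O)c2ccc(N3CCNC3=O)cc2)c1` is not yet measured; it differs from compound 3 by 3-methylphenyl in place of 2,4-dimethylphenyl on a sulfonamide nitrogen. The measured steps that bear on this change all swap the group on the sulfonamide nitrogen: a 1.6-fold lower number from compound 1 to compound 2 (0.20 log units; within the scatter), a 3.2-fold lower number from compound 1 to compound 3 (0.51 log units; beyond the scatter) and a 2.0-fold lower number from compound 2 to compound 3 (0.30 log units; within the scatter). Such swaps have moved the number by small to modest amounts, so the smaller aryl group of compound 4 is expected to bring a modest rise at most, a 1.7-fold higher number from compound 3 to compound 4 (0.24 log units; within the scatter). Compound 4 is therefore estimated at 260 nM, within a range of 120 nM to 600 nM.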

Compound 4, half-maximal inhibitory concentration: 69 nM
The estimate for compound 4 lay 3.8-fold (0.58 log units) above the measured number; measured number below the stated range.
By their numbers in this assay, from the lowest: compound 4; then compounds 3, 2 and 1 (each within the scatter of the next, the first and the last beyond it).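

In this assay the smaller 3-methylphenyl group in place of 2,4-dimethylphenyl on the sulfonamide nitrogen gives a 2.2-fold lower number from compound 3 to compound 4 (0.34 log units; beyond the scatter) and so costs nothing; a larger aryl group is not needed here. Among the compounds shown here, the steps of a 4.3-fold lower number from compound 2 to compound 4 (0.64 log units; beyond the scatter) and of a 7.0-fold lower number from compound 1 to compound 4 (0.84 log units; beyond the scatter) show that this position responds more strongly to the choice of aryl group than the earlier steps suggested. No available evidence explains why this swap lowers the number.

Still open, on these data alone, is how a plain phenyl group would compare. So is whether an aryl group carrying an amine or a carboxylic acid would keep the number this low.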